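The compounds below may be only part of what the source reports. "The series", "measured", "known", "first", "only" and "open" are said of these compounds alone.

For the measured compounds named here, in a functional assay on HL-60 cells (Homo sapiens) for inhibition, read by CellTiter-Glo, with a stated time of 48 h (on this read-out higher numbers stand for weaker inhibition of growth and lower numbers for stronger inhibition of growth), compound 3 `O=C(CCCCCCN1C/C=C/COCc2cccc(c2)-c2ccnc(n2)Nc2cccc(c2)C1)NO` gives 900 nM, the lowest of the three numbers so far. Compound 2 `O=C(CCCCN1C/C=C/CCOc2cccc(c2)-c2ccnc(n2)Nc2cccc(c2)C1)NO` gives 3030 nM, and compound 1 `O=C(CCCCC(=O)N1C/C=C/COCc2cccc(c2)-c2ccnc(n2)Nc2cccc(c2)C1)NO` gives 4430 nM.

Compound 4 `O=C(CCCCCCC(=O)N1C/C=C/COCc2cccc(c2)-c2ccnc(n2)Nc2cccc(c2)C1)NO` keeps the core of compound 3 and changes only the chain on an amine nitrogen in a ring, with (6-(hydroxycarbamoyl)hexyl)carbonyl in place of 6-(hydroxycarbamoyl)hexyl on an amine nitrogen in a ring. The chain name stays the same, and a carbonyl now sits on that nitrogen, as it also does in compound 1.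

Going by the values given here, one measured step bears on this change: a 4.9-fold lower number from compound 1 to compound 3 (0.69 log units; beyond the scatter). That modest step swapped (4-(hydroxycarbamoyl)butyl)carbonyl for 6-(hydroxycarbamoyl)hexyl, so the carbonyl and the chain changed together, and the data cannot separate the two. Compound 2 differs from compound 3 in more than one place, so it gives no clean comparison. Compound 4 brings back the carbonyl but keeps the hexyl chain name, so only part of the step to compound 3 is expected to be undone, and a smaller move towards a higher number, meaning weaker inhibition of growth, is expected in this assay.

The expected change is a 2.2-fold higher number from compound 3 to compound 4 (0.35 log units; beyond the scatter).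

For compound 4 the estimate is 2000 nM, with an expected range from 700 nM to 5000 nM.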

Compound 4, concentration for 50% growth inhibition: 2870 nM
Compound 4: the middle estimate sits 1.4-fold (0.16 log units) below what was measured; low and high end bracket the measured number.
By their numbers in this assay, from the lowest: compound 3; then compounds 4, 2 and 1 (each within the scatter of the next).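

The carbonyl on the amine nitrogen in a ring can now be looked at alone, and in this assay adding it to the hexyl chain is a modest change beyond the scatter (a 3.2-fold higher number from compound 3 to compound 4 (0.50 log units; beyond the scatter)). The chain can also be looked at alone with the carbonyl in place: going from (4-(hydroxycarbamoyl)butyl)carbonyl to (6-(hydroxycarbamoyl)hexyl)carbonyl stays within the scatter (a 1.5-fold lower number from compound 1 to compound 4 (0.19 log units; within the scatter)), so among these compounds the advantage of compound 3 goes with the missing carbonyl, not with the chain name. No measurement here gives a reason for this difference.

Still open, on these data alone, is whether removing the carbonyl helps on the shorter chain as well, since 4-(hydroxycarbamoyl)butyl appears without a carbonyl only in compound 2, which differs from compound 3 in more than one place and so gives no clean comparison. As far as these compounds go, it is also open how a longer chain on this nitrogen, or a carboxylic acid in place of the hydroxycarbamoyl group, would behave on the shared core.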